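Benzylamino for Benzylsulfanyl on a Thiocarbonyl Carbon

A few compounds are considered here, and "the series" means these few. Any claim that something is new, unique, unknown or untested is made for them only; others in the source may bear on it.

Compound 3 `CN(C)C(=S)SC(=S)N1CCN(C(=S)SCc2ccccc2)CC1` was tested in an ADME assay on HeLa cells (Homo sapiens) for cytotoxicity, read by MTT assay, with a stated time of 24 h; on this read-out higher numbers stand for weaker inhibition and lower numbers for stronger inhibition. In this assay compound 3 gives > 5000000 nM, which is a limit of the assay rather than a number. Compound 1 `CSC(=S)N1CCN(C(=S)SC(=S)N(C)C)CC1` is its closest relative. In this assay compound 1 gives > 5000000 nM, again a limit. Compound 2 `CCSC(=S)N1CCN(C(=S)SC(=S)N(C)C)CC1` in this assay gives 4480000 nM. Two of the three values therefore rest at the limit of > 5000000 nM in this assay, at which 2 of the 3 values shown sit. The measured steps are an at least 1.1-fold lower number from compound 1 to compound 2 (0.04 log units; that floor lies within the scatter) and an at least 1.1-fold higher number from compound 2 to compound 3 (0.04 log units; that floor lies within the scatter), while a step that the two limits leave unreadable from compound 1 to compound 3.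

Compound 4 `CN(C)C(=S)SC(=S)N1CCN(C(=S)NCc2ccccc2)CC1` differs from compound 3 by benzylamino in place of benzylsulfanyl on a thiocarbonyl carbon. For the measured compounds named here, none of the measured steps alters the thiocarbonyl carbon; each of them changes the group on a saturated chain carbon bound to a sulfur, and none of them rises beyond the scatter. In this assay the expected step is a number no higher from compound 3 to compound 4 (the limit leaves the size open), nothing beyond the scatter. Compound 4 is estimated at 5000000 nM, in the range from 2500000 nM to 10000000 nM, and is expected most likely to be reported as a limit once more.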

Compound 4, half-maximal inhibitory concentration: > 5000000 nM
Compound 4: a limit, no number; the forecaster's own chance of this, stated with the estimate: 75%; the middle value lies on the limit itself.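

Unlike the earlier steps, which changed only the group on a saturated chain carbon bound to a sulfur, benzylamino in place of benzylsulfanyl alters what sits on the thiocarbonyl carbon itself, and in this assay this brings no sign of stronger inhibition. For the compounds shown here, the one step that can be read is an at least 1.1-fold higher number from compound 2 to compound 4 (0.04 log units; that floor lies within the scatter), while the steps to compound 4 from compound 1 and compound 3 cannot be read. Exchanging the sulfur for a nitrogen bearing a hydrogen therefore gives no measurable separation here, and the series remains crowded: the limit of > 5000000 nM in this assay, at which 3 of the 4 values shown sit.

On these data alone, how far compound 1, compound 3 and compound 4 lie beyond that limit stays open. So does whether a dimethylamino group on the thiocarbonyl carbon, or a carboxylic acid on the phenyl ring, would bring a value clearly inside the range of this assay.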